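The source may report more compounds than this note shows. Statements on the series, on what has been measured and on what is new or still open speak of the compounds shown alone.

Compound 1 `Sc1nnc(-c2ccc3c(c2)OCCO3)n1-c1ccccc1` carries an unsubstituted sulfur on the shared core and in a functional assay on HepG2 cells (Homo sapiens) for antiproliferative activity, read by MTT assay, with a stated time of 24 h (on this read-out higher numbers stand for weaker inhibition and lower numbers for stronger inhibition), compound 1 gives 60000 nM. Compound 2 `c1ccc(CSc2nnc(-c3ccc4c(c3)OCCO4)n2-c2ccccc2)cc1` adds a benzyl to that sulfur, and in this assay compound 2 gives 5960 nM, the second highest of the three numbers: a 10-fold lower number from compound 1 to compound 2 (1.00 log units; beyond the scatter). Compound 3 `Fc1cccc(F)c1CSc1nnc(-c2ccc3c(c2)OCCO3)n1-c1ccccc1` goes further, with a 29-fold lower number from compound 1 to compound 3 (1.46 log units; beyond the scatter) and a 2.9-fold lower number from compound 2 to compound 3 (0.46 log units; beyond the scatter); in this assay compound 3 gives 2070 nM.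

Compound 4 `Brc1ccc(CSc2nnc(-c3ccc4c(c3)OCCO4)n2-c2ccccc2)cc1` differs from compound 2 in one place: bromo in place of hydrogen on an aromatic carbon, on an aromatic carbon of a six-membered aromatic ring of carbon only, para to a large group. Among the compounds with values here, no measured step shows a single bromo entering anywhere. Within the data shown here, the only step that bears on it is a 2.9-fold lower number from compound 2 to compound 3 (0.46 log units; beyond the scatter), where halogen on the benzyl ring lowered the number, but that change differs in kind and count, so the bearing is loose. A smaller lowering, near the edge of the scatter, is therefore expected for compound 4, namely a 1.7-fold lower number from compound 2 to compound 4 (0.23 log units; within the scatter), with an estimated value of 3500 nM and a range from 1500 nM to 9000 nM.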

Compound 4, half-maximal inhibitory concentration: 7940 nM
Estimate against measurement, compound 4: 2.3-fold (0.36 log units) below; the range from low to high includes it.
By their numbers in this assay, from the lowest: compound 3; then compounds 2 and 4 (each within the scatter of the next); then compound 1.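

In this assay, 4-bromobenzyl on the sulfur cannot be told apart from benzyl, with a 1.3-fold higher number from compound 2 to compound 4 (0.12 log units; within the scatter), so a single bromo at this position, para to a large group, shows no measurable effect. The lower number seen with 2,6-difluorobenzyl therefore does not extend to every halogenated benzyl, with a 3.8-fold higher number from compound 3 to compound 4 (0.58 log units; beyond the scatter), whereas the lowering that comes with a substituent on the sulfur persists, with a 7.6-fold lower number from compound 1 to compound 4 (0.88 log units; beyond the scatter). Nothing available accounts for the difference between these two halogenated benzyl groups. On these data alone, it remains open whether the result for compound 3 follows from fluoro as such or from where it sits, which 4-fluorobenzyl or 2-bromobenzyl could separate. Also open, as far as these compounds go, is how an amine or a carboxylic acid on that ring, or a longer chain on the sulfur, would compare.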